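A few compounds are considered here, and "the series" means these few. Any claim that something is new, unique, unknown or untested is made for them only; others in the source may bear on it.

Measured so far:
Compound 1, `OC[C@@H](O[C@H]1CCCN(Cc2ncc[nH]2)[C@H]1c1ccccc1)c1cc(Cl)cc(Cl)c1`, in an assay on isolated protein for activation of cGMP-dependent protein kinase 1 (Homo sapiens), read by ADP-Glo, with stated times of 30 min and 2 h, in the presence of a further agent that is not named here (on this read-out higher numbers stand for an effect only at larger amounts of compound and lower numbers for an effect already at smaller amounts), gives 47000 nM.
Compound 2, `OC[C@@H](O[C@H]1CCCN(Cc2nc3ccccc3[nH]2)[C@H]1c1ccccc1)c1cc(Cl)cc(Cl)c1`, in this assay gives 4700 nM.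
Compound 3, `Cc1cc(C(=O)O)ccc1CN1C(C)CC[C@H](O[C@H](CO)c2cc(Cl)cc(Cl)c2)[C@@H]1c1ccccc1`, in this assay gives 36000 nM.

Compound 2 stands lowest of the three in this assay, with compound 3 nearest and compound 1 furthest. Compound 4, `Nc1cc(C(=O)O)ccc1CN1CCC[C@H](O[C@H](CO)c2cc(Cl)cc(Cl)c2)[C@@H]1c1ccccc1`, has not yet been measured; it differs from compound 2 in one place: 2-amino-4-carboxyphenyl in place of 1H-benzimidazol-2-yl on a saturated chain carbon bound to an amine nitrogen in a ring.

Among the compounds with values here, only one measured step touches this position, a 10-fold lower number from compound 1 to compound 2 (1.00 log units; beyond the scatter), and it shows that the group on this carbon matters in this assay. Compound 3, which carries a carboxyphenyl group at the same position together with other changes, gives a clearly higher number than compound 2 in this assay. Within the data shown here, no step for the exchange of the benzimidazolyl group against the aminocarboxyphenyl group itself exists. Compound 4 is therefore expected to show a higher number than compound 2, and the expected step is a 5.3-fold higher number from compound 2 to compound 4 (0.73 log units; beyond the scatter). Compound 4 is estimated at 25000 nM in this assay, within a range from 8000 nM to 80000 nM.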

Compound 4, half-maximal effective concentration: 290 nM
Compound 4: the middle estimate sits 86-fold (1.94 log units) above what was measured, outside the stated range (below it).
By their numbers in this assay, from the lowest: compound 4; then compound 2; then compounds 3 and 1 (each within the scatter of the next).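

On the saturated chain carbon bound to an amine nitrogen in a ring, 2-amino-4-carboxyphenyl in this assay gives a 16-fold lower number from compound 2 to compound 4 (1.21 log units; beyond the scatter) and, against the 1H-imidazol-2-yl group, a 160-fold lower number from compound 1 to compound 4 (2.21 log units; beyond the scatter). At this place, then, a group with one six-membered aromatic ring of carbon only, bearing an amine and a carboxylic acid, goes well past the 1H-benzimidazol-2-yl group, so a fused ring with hetero atoms is not needed for a low number here. Nothing available explains this change in the number.

The compounds shown leave open how much of the step belongs to the amine and how much to the carboxylic acid, which a benzyl group carrying only one of them would separate. Going by these compounds, whether a methyl ester or an amide in place of the carboxylic acid keeps the low number also remains open.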